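The compounds below may be only part of what the source reports. "The series", "measured", "known", "first", "only" and "open" are said of these compounds alone.

Measured so far in an ADME assay on J774.A1 cells (Mus musculus) for cytotoxicity, read by MTT assay, with a stated time of 48 h; on this read-out higher numbers stand for lower toxicity in this test and lower numbers for higher toxicity in this test:
- compound 1 `Cc1nc2ccc(Cl)cc2c(-c2ccccc2)c1C(=O)OCc1cn(-c2ccc(C(C)C)cc2)nn1`: "not determined" (no result reported)
- compound 2 `Cc1ccc(-n2cc(COC(=O)c3c(C)nc4ccccc4c3-c3ccccc3)nn2)cc1F`: 36000 nM

Among the measured compounds shown here, compound 2 holds the only number in this small set, so it cannot yet be ranked as high or low against a neighbour. Compound 1 offers no comparison, since it has no result. Compound 3 `Cc1ccc(-n2cc(COC(=O)c3c(C)nc4ccc(Cl)cc4c3-c3ccccc3)nn2)cc1F` is built from compound 2 by a single change: chloro in place of hydrogen on an aromatic carbon. In plain terms, this is chloro in place of hydrogen on an aromatic carbon. For the measured compounds named here, no measured pair shows what this swap does in this assay, so the expectation rests on compound 2 at 36000 nM alone. With no evidence for a large shift, only a small move is expected, and the estimated 1.2-fold lower number from compound 2 to compound 3 (0.08 log units; within the scatter) stays within the usual scatter. For compound 3 the expected value is 30000 nM, with an estimated range from 12000 nM to 75000 nM.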

Compound 3, half-maximal cytotoxic concentration: 34000 nM
Compound 3: middle estimate off by 1.1-fold (0.05 log units), on the low side; measured number inside the range.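

Chloro in place of hydrogen on an aromatic carbon of the fused two-ring system gives a 1.1-fold lower number from compound 2 to compound 3 (0.02 log units; within the scatter) in this assay, so this test cannot tell the two compounds apart. Among the compounds shown here, this is the first step that can be read in the set, and it shows that adding this one chlorine atom at this position makes no difference beyond the usual scatter in the toxicity reading. Nothing available explains why the two numbers sit so close.

A single chloro at one place cannot show how different groups would behave there, such as an amine, a carboxylic acid or a longer chain. Compound 1 also carries chloro at this place, but with "not determined" (no result reported) it adds no comparison.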